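The source may hold more compounds than are shown below. What is called first, only, known or untested is meant among the compounds shown, and "the series" means these compounds.

Three compounds share one core and differ only in the side chain attached to it. Compound 1 `CCC(=CCc1c(O)cc2c(c1O)C(=O)CC(c1ccc(O)cc1)O2)CC` carries a branched open chain and gives 260 nM in an assay on HEK293 cells for inhibition of Voltage-dependent T-type calcium channel subunit alpha-1H (Homo sapiens), read by patch clamp, with a stated time of 10 min; a higher number here means a weaker inhibitor, a lower number a stronger inhibitor. Compound 2 `O=C1CC(c2ccc(O)cc2)Oc2cc(O)c(CC=C3CCCC3)c(O)c21` carries a five-membered ring on that chain and gives 460 nM. Compound 3 `CC(C)CCc1c(O)cc2c(c1O)C(=O)CC(c1ccc(O)cc1)O2` carries a shorter open chain and gives 480 nM. On these numbers compound 3 holds the highest of the three values, but the gaps are small: a 1.0-fold higher number from compound 2 to compound 3 (0.02 log units; within the scatter) and a 1.8-fold higher number from compound 1 to compound 3 (0.27 log units; within the scatter), and likewise a 1.8-fold higher number from compound 1 to compound 2 (0.25 log units; within the scatter).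

Compound 4 `O=C1CC(c2ccc(O)cc2)Oc2cc(O)c(CCC3CCCC3)c(O)c21` is compound 3 with one change: cyclopentyl in place of isopropyl on a saturated chain carbon, two bonds along the chain from an aromatic carbon. All three measured steps bear on this, since each swaps one carbon group for another at the same side chain, and each stayed within the scatter, including the one that exchanged an open chain for a five-membered ring. Among the compounds with values here, nothing among the measured compounds points to a shift beyond the scatter when a ring replaces a branched chain here, so the step from compound 3 to compound 4 is expected to be small, a 1.1-fold lower number from compound 3 to compound 4 (0.06 log units; within the scatter). Compound 4 is therefore estimated at 420 nM, with a likely range from 180 nM to 1000 nM.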

Compound 4, half-maximal inhibitory concentration: 500 nM
Compound 4: the middle estimate sits 1.2-fold (0.08 log units) below what was measured; the measured number falls inside the stated range.
By their numbers in this assay, from the lowest: compounds 1, 2, 3 and 4 (each within the scatter of the next).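

Cyclopentyl in place of isopropyl, on a saturated chain carbon two bonds along the chain from an aromatic carbon, gives a 1.0-fold higher number from compound 3 to compound 4 (0.02 log units; within the scatter) in this assay and so stays within the scatter, which shows that a five-membered ring is tolerated here on a chain with no double bond, whereas the earlier ring compound, compound 2, had one. The pair that isolates that double bond gives a 1.1-fold higher number from compound 2 to compound 4 (0.04 log units; within the scatter) and also stays within the scatter, so in these two compounds the ring reads the same with the double bond or without it. The widest new comparison, a 1.9-fold higher number from compound 1 to compound 4 (0.28 log units; within the scatter), sets the saturated ring chain against the branched open chain of compound 1 and is likewise within the scatter, leaving all four side chains indistinguishable in this measurement.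

Every side chain shown is built of carbon and hydrogen alone, so it remains open how an amine, a carboxylic acid or a much longer chain would read at this position. Nothing available explains why these side chains read alike.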